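The compounds below may be only part of what the source reports. "The series", "measured", "known", "first", "only" and "open" are said of these compounds alone.

Compound 1 `C/C(=N/NC(=O)Nc1nc(-c2ccc(C)cc2)cc(-c2ccc(F)cc2)n1)c1ccc([N+](=O)[O-])cc1` gives 300 mg/kg in a functional assay on the whole organism (strain Albino) with Mus musculus as the target, with a stated time of 4 h; a higher number here means that more compound is needed for the effect, a lower number that less compound is needed. Compound 3 `COc1ccc(-c2cc(-c3ccc(Cl)cc3)nc(NC(=O)N/N=C\c3ccccc3Cl)n2)c(OC)c1` gives 300 mg/kg in this assay, no change at the digits and within the scatter, so the two together hold the highest number of the three. Among the measured compounds shown here, compound 2 `C/C(=N/NC(=O)Nc1nc(-c2ccc(C)cc2)cc(-c2ccc(F)cc2)n1)c1ccc(Cl)cc1` gives 100 mg/kg in this assay; the one measured single-point step is a 3.0-fold lower number from compound 1 to compound 2 (0.48 log units; beyond the scatter), chloro in place of nitro on an aromatic carbon.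

Compound 4 `C/C(=N/NC(=O)Nc1nc(-c2ccc(C)cc2)cc(-c2ccc(Cl)cc2)n1)c1ccc([N+](=O)[O-])cc1` differs from compound 1 by chloro in place of fluoro on an aromatic carbon. For the measured compounds named here, no measured pair in this set shows chloro in place of fluoro: the step of a 3.0-fold lower number from compound 1 to compound 2 (0.48 log units; beyond the scatter) changes a different group, and compound 3 differs from compound 1 in several places at once, so its value bears no single-change reading. Going by the values given here, the step from compound 1 to compound 4 thus has no direct precedent, and no movement beyond the scatter is expected in this assay. Compound 4 is expected to give 300 mg/kg, in the range 120 mg/kg to 600 mg/kg. That estimate corresponds to no change at the digits printed from compound 1 to compound 4 (within the scatter), expected to lie within the scatter.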

Compound 4, dose for half-maximal effect: 300 mg/kg
Compound 4: the middle estimate sits on the measured number at the digits printed; the measured number falls inside the stated range.
By their numbers in this assay, from the lowest: compound 2; then compounds 1, 3 and 4 (each within the scatter of the next).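

In this assay, chloro in place of fluoro on an aromatic carbon para to a large group gives no change at the digits printed from compound 1 to compound 4 (within the scatter). Among the compounds shown here, this is the first single-change reading at this position, whereas the earlier step, a 3.0-fold lower number from compound 1 to compound 2 (0.48 log units; beyond the scatter), lies beyond the scatter but changes a different group, so the number has so far moved with the nitro replacement and not with the 4-fluorophenyl to 4-chlorophenyl change. No measurement here bears on why the two halogens read alike.

As far as these compounds go, this reading rests on a single pair carrying nitro, so it remains open whether the same halogen change would read alike with the chloro of compound 2 in that place. Also open, from the compounds shown here alone, is whether an amine or a carboxylic acid at this position would shift the number beyond the scatter.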